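From propanoyl to benzoyl on the ring nitrogen

The source may report more compounds than this note shows. Statements on the series, on what has been measured and on what is new or still open speak of the compounds shown alone.

Measured compounds:
compound 1 `O=C(Nc1cc(C(F)(F)F)cc(C(F)(F)F)c1)C1CCc2ccccc2N1C(=O)c1ccccc1Cl` gives 4700 nM
compound 2 `CCCC(=O)N1c2ccccc2CCC1C(=O)Nc1ccccc1C(F)(F)F` gives > 70000 nM
compound 3 `CCC(=O)N1c2ccccc2CCC1C(=O)Nc1ccccc1C(F)(F)F` gives > 80000 nM

In a functional assay on ACHN cells (Homo sapiens) for cytotoxicity, read by sulforhodamine B assay, with a stated time of 72 h (a higher number here means a weaker inhibitor of growth, a lower number a stronger inhibitor of growth), compound 3 gives only a limit, > 80000 nM, and no number. Compound 2 likewise gives only a limit, > 70000 nM. Compound 1 gives a measured value, 4700 nM, the one real number shown. Among the measured compounds shown here, the single measured step, a step that the two limits leave unreadable from compound 2 to compound 3, is therefore unreadable, since both ends sit at limits (the limit of > 70000 nM in this assay, at which 1 of the 3 values shown sits, and (the limit of > 80000 nM in this assay, at which 1 of the 3 values shown sits)), and it tells nothing about how the group on the ring nitrogen shapes growth inhibition.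

Compound 4 `O=C(Nc1ccccc1C(F)(F)F)C1CCc2ccccc2N1C(=O)c1ccccc1` differs from compound 3 in one place: phenyl in place of ethyl on a carbonyl carbon. For the measured compounds named here, no measured step covers this change. Going by the values given here, the only hint comes from compound 1, which carries an aroyl group on the ring nitrogen and reaches a measured number, but compound 1 also differs from compound 4 in its chlorine and in its aryl amide, so that comparison is loose. The expectation is that compound 4 lands somewhere between the limit of compound 3 and the number of compound 1, with a wide range. Compound 4 is estimated at 25000 nM, from 5000 nM to 100000 nM. This corresponds to an expected step of an at least 3.2-fold lower number from compound 3 to compound 4 (0.50 log units; beyond the scatter), with a real chance that only a limit is reported again.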

Compound 4, concentration for 50% growth inhibition: 8090 nM
Beside the measured number, compound 4's estimate is 3.1-fold (0.49 log units) above it; low and high end bracket the measured number.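

In this assay, putting phenyl in place of ethyl on the carbonyl carbon gives an at least 9.8-fold lower number from compound 3 to compound 4 (0.99 log units; beyond the scatter), and putting phenyl in place of propyl at the same carbon gives an at least 8.6-fold lower number from compound 2 to compound 4 (0.93 log units; beyond the scatter). Among the compounds shown here, this is the first readable change at this position: the two open chains could not be told apart, whereas moving from either chain to phenyl brings growth inhibition that can be given as a number. The true size of the first step may be larger because compound 3 gives only a limit and no number: the limit of > 80000 nM in this assay, at which 1 of the 4 values shown sits.

On these data alone, what remains open is whether an aromatic ring is needed at this carbonyl carbon, or whether a saturated ring such as cyclohexyl, or a pyridine ring, would serve as well. Compound 1 differs from compound 4 in more than one place, so the separate contributions of its chlorine and of its different aryl amide remain unresolved.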